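Chlorobenzyl to Fluorobenzyl: What to Expect

The source may report more compounds than this note shows. Statements on the series, on what has been measured and on what is new or still open speak of the compounds shown alone.

Measured so far:
compound 1 `COc1ccc(C2N=C(SCc3ccccc3)NC(C)=C2C(=O)Nc2ccc(F)cc2)cc1OC`: 7.2%
compound 2 `CC1=C(C(=O)Nc2ccc(Br)cc2)C(c2ccc(Cl)cc2Cl)N=C(SCc2ccccc2Cl)N1`: 36.4%

Of the compounds shown here, two have been measured in a functional assay on the whole organism (artery, strain albino) with Rattus norvegicus as the target, with a stated time of 300 min, at a dose of 10 mg/kg by the oral route; on this read-out higher numbers stand for more inhibition at the one dose given (going by the name of the read-out) and lower numbers for less inhibition. Compound 1 gives 7.2%, and compound 2 gives 36.4%. For the measured compounds named here, on these two numbers compound 2 stands highest; its only neighbour, compound 1, lies lower by a margin beyond the usual scatter. The two measured compounds differ in more than one place, so no single step can be read between them.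

Compound 3 `CC1=C(C(=O)Nc2ccc(Br)cc2)C(c2ccc(Cl)cc2Cl)N=C(SCc2ccc(F)cc2)N1` has not been measured. It differs from compound 2 in one place only, namely (4-fluorophenyl in place of 2-chlorophenyl on a saturated chain carbon bound to a sulfur). Going by the values given here, no measured step of the same kind exists to lean on, so the expectation for compound 3 in this assay rests on the value of compound 2 alone, with a change expected to be small, leaning slightly downward, and most likely within the scatter. Compound 3 is expected to give about 30%, within a range from 12% to 50%. The expected step is a number 6.4 percentage points lower from compound 2 to compound 3 (within the scatter).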

Compound 3, a percentage reported as inhibition, in the whole organism at one dose (the size of the read-out at that dose, not a potency): 38.5%
Compound 3: the middle estimate sits 8.5 percentage points below what was measured; measured number inside the range.
By their numbers in this assay, from the lowest: compound 1; then compounds 2 and 3 (each within the scatter of the next).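

In this assay, for the compounds shown here, putting 4-fluorophenyl in place of 2-chlorophenyl on a saturated chain carbon bound to a sulfur gives a number 2.1 percentage points higher from compound 2 to compound 3 (within the scatter), the first step in this set that can be read at a single place. With the rest of the structure held fixed, the two groups cannot be told apart at the one dose given, so this position accepts either of them in this read-out. Nothing measured here explains that likeness.

This single step alters both the halogen and its ring position, so it cannot separate the two changes, and a 4-chlorophenyl group would be needed to do so. On these data alone, how a ring carrying an amine or a carboxylic acid, or a longer chain between the sulfur and the ring, would read at this position remains open.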